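A Lighter Group on the Oxygen of Compound 1

The source may hold more compounds than are shown below. What is called first, only, known or untested is meant among the compounds shown, and "the series" means these compounds.

Among the measured compounds shown here, compound 1 `CCOC(=O)c1csc(CO/N=C(\C)c2ccc(Sc3cc(F)cc(C4CCOCC4)c3)cc2)n1` is one of three compounds measured in a functional assay (blood) for inhibition, with Homo sapiens as the target; a lower number here means a stronger inhibitor, a higher number a weaker inhibitor. In that setting compound 1 gives 150 nM, the highest of the three numbers. Compound 3 `CO[C@]1(c2cnc(S(=O)(=O)c3ccc(/C(C)=N/OCC#N)cc3)s2)CCO[C@@H](C)C1` gives 140 nM, which lies within the usual scatter of the value of compound 1, so the two cannot be told apart. Compound 2 `COC1(c2cc(F)cc(Sc3ccc4c(c3)OCC/C4=N\O)c2)CCOCC1` gives 50 nM, a number that sits beyond the scatter below compound 1, making compound 2 the stronger inhibitor of that pair.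

Compound 4 `C/C(=N\OC(=O)C(C)(C)C)c1ccc(Sc2cc(F)cc(C3CCOCC3)c2)cc1` has not yet been measured in this assay. It differs from compound 1 in a single place: (tert-butyl)carbonyl in place of (4-(ethoxycarbonyl)-1,3-thiazol-2-yl)methyl on an oxygen. The group that leaves carries a ring and several hydrogen-bond acceptors; the group that enters has no ring and a single acceptor.

For the measured compounds named here, no step between measured compounds that differ in one place is available, so the outcome has to be estimated from the spread of the three values. Since compound 3 gives 140 nM, close to compound 1 despite a different arrangement at that oxygen, a modest step of a 1.4-fold lower number from compound 1 to compound 4 (0.13 log units; within the scatter) toward a somewhat lower number is expected for compound 4. Compound 4 is therefore expected to give 110 nM in this assay, within a range from 45 nM to 300 nM.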

Compound 4, half-maximal inhibitory concentration: 40 nM
Beside the measured number, compound 4's estimate is 2.8-fold (0.44 log units) above it; measured number outside the range, below it.
By their numbers in this assay, from the lowest: compounds 4 and 2 (each within the scatter of the next); then compounds 3 and 1 (each within the scatter of the next).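

In this assay, among the compounds shown here, the exchange on the oxygen whose other neighbours are double-bonded nitrogen gives a 3.8-fold lower number from compound 1 to compound 4 (0.57 log units; beyond the scatter) and supplies the first step in this set between two compounds that differ in one place. It shows that (4-(ethoxycarbonyl)-1,3-thiazol-2-yl)methyl is not required on this oxygen for a low number in this setting: (tert-butyl)carbonyl, which has no ring and fewer heavy atoms and hydrogen-bond acceptors, gives a clearly lower number on the same core. The compounds offer no measured basis for explaining this step.

For the compounds shown here, the two groups differ at once in ring, size and number of acceptors, and the single step cannot show which of these differences tracks the lower number. Still open, on these data alone, is whether a smaller acetyl group or a plain methyl on the same oxygen would keep the lower number, and whether a carboxylic acid in place of the ethyl ester of the thiazole group would change the number of compound 1.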